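Methyl entering the aromatic ring of compound 3

A few compounds are considered here, and "the series" means these few. Any claim that something is new, unique, unknown or untested is made for them only; others in the source may bear on it.

Three ureas have been run in an ADME assay on the whole organism with Oryza sativa as the target, tested at 1 uM; on this read-out higher numbers stand for a weaker effect at the one concentration tested and lower numbers for a stronger effect. Compound 1 `CCCCCc1ccc(NC(=O)N[C@H](C)c2ccccc2)cc1` gives 101%, compound 2 `CC(=O)c1ccc(NC(=O)N[C@H](C)c2ccccc2)cc1` gives 93%, and compound 3 `C[C@@H](NC(=O)Nc1ccc(F)cc1)c1ccccc1` gives 96%. Compound 3 sits second highest of the three numbers, but every step among them stays within the scatter: a number 8 percentage points lower from compound 1 to compound 2 (within the scatter), a number 5 percentage points lower from compound 1 to compound 3 (within the scatter) and a number 3 percentage points higher from compound 2 to compound 3 (within the scatter). Exchanging pentyl, acetyl and fluoro on that aromatic carbon thus moves this assay by no more than the noise.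

Compound 4 `Cc1cc(F)ccc1NC(=O)N[C@H](C)c1ccccc1` differs from compound 3 by methyl in place of hydrogen on an aromatic carbon. Among the measured compounds shown here, none of the three measured steps touches the same aromatic carbon, so no step bears on it directly; the nearest analogy is that three substituent changes on the same ring all remained within the scatter. On that basis the expected step is no change at the digits printed from compound 3 to compound 4 (within the scatter), with no direction beyond the scatter. Compound 4 is expected to give 96%, in a range from 85% to 105%.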

Compound 4, a percentage reported as activity, at one concentration (the size of the read-out at that concentration, not a potency): 100%
Compound 4: the middle estimate sits 4 percentage points below what was measured; measured number inside the range.
By their numbers in this assay, from the lowest: compounds 2, 3, 4 and 1 (each within the scatter of the next).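

Methyl in place of hydrogen, ortho to a large group and meta to a fluoro group, gives in this assay a number 4 percentage points higher from compound 3 to compound 4 (within the scatter). The earlier steps shown here only exchanged one group for another on a single aromatic carbon, whereas this step fills a further ring carbon, and this small addition does not separate the two compounds on this read-out. No measured evidence accounts for this result.

On these data alone, whether another group on this carbon, such as methoxy, an amine or a carboxylic acid, would move the read-out beyond the scatter remains open. Also open, as far as these compounds go, is whether methyl here would give the same picture with pentyl or acetyl in place of the fluoro group.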